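Pyrazoline amides: aryl exchange on the saturated ring carbon

The source may report more compounds than this note shows. Statements on the series, on what has been measured and on what is new or still open speak of the compounds shown alone.

Compound 1 `COc1ccc(C2=NN(C(=O)CO[N+](=O)[O-])C(c3ccco3)C2)cc1OC` gives 37% in a functional assay on the whole organism (strain albino) for inhibition, with Rattus norvegicus as the target, read by paw edema, with stated times of 30 min and 2 h, at a dose of 100 mg/kg by the oral route; a lower number here means less inhibition, a higher number more inhibition at the dose given (going by the name of the read-out). Compound 2 `COc1ccc(C2CC(c3ccc(OC)c(OC)c3)=NN2C(=O)CO[N+](=O)[O-])c(OC)c1` gives 48% in this assay, the step of a number 11 percentage points higher from compound 1 to compound 2 (beyond the scatter) following from 2,4-dimethoxyphenyl in place of furan-2-yl on a saturated ring carbon. Compound 3 `COc1ccc(C2=NN(C(=O)C(C)Br)C(c3ccco3)C2)cc1OC` gives 36% in this assay; its core differs from that of compound 1 by 1-bromoethyl in place of (nitrooxy)methyl on a carbonyl carbon, a step of a number 1 percentage points lower from compound 1 to compound 3 (within the scatter). Compound 4 `COc1ccc(C2CC(c3ccc(OC)c(OC)c3)=NN2C(=O)C(C)Br)c(OC)c1` is not yet measured in this assay. It differs from compound 3 by 2,4-dimethoxyphenyl in place of furan-2-yl on a saturated ring carbon, the same kind of change as between compound 1 and compound 2 but not the same: the place in compound 3 is next to the ring atom that bears a (1-bromoethyl)carbonyl group (5 heavy atoms), whereas in compound 1 it is next to the ring atom that bears a ((nitrooxy)methyl)carbonyl group (7 heavy atoms). The expected step is a number 11 percentage points higher from compound 3 to compound 4 (beyond the scatter), set beside a number 11 percentage points higher from compound 1 to compound 2 (beyond the scatter) because a number 1 percentage points lower from compound 1 to compound 3 (within the scatter) lies within the scatter, so the two cores behave alike so far. Compound 4 is therefore expected to give 47% in this assay, estimated between 35% and 59%.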

Compound 4, a percentage reported as inhibition, in the whole organism at one dose (the size of the read-out at that dose, not a potency): 63%
The estimate for compound 4 lay 16 percentage points below the measured number; the whole stated range lies below it.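

On the core with the (1-bromoethyl)carbonyl group, 2,4-dimethoxyphenyl in place of furan-2-yl gives a number 27 percentage points higher from compound 3 to compound 4 (beyond the scatter), so in this assay the size of this step does not carry over unchanged: the same change on two cores in this assay, a number 11 percentage points higher (beyond the scatter) from compound 1 to compound 2 and a number 27 percentage points higher (beyond the scatter) from compound 3 to compound 4, 16 percentage points apart, beyond the scatter of two such steps

The exchange on the carbonyl carbon, 1-bromoethyl in place of (nitrooxy)methyl, gives a number 15 percentage points higher from compound 2 to compound 4 (beyond the scatter), so its outcome also differs with the group on the saturated ring carbon: the same change on two cores in this assay, a number 1 percentage points lower (within the scatter) from compound 1 to compound 3 and a number 15 percentage points higher (beyond the scatter) from compound 2 to compound 4, 16 percentage points apart, beyond the scatter of two such steps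

The aryl exchange raises the number on both cores, but the four compounds do not show why the sizes differ or how the step would run on a further core.

Open, from the compounds shown here alone, is whether a plain phenyl or a thiophen-2-yl on the saturated ring carbon would show the same dependence on the core. Also open, going by these compounds, is how a chloromethyl or an aminomethyl on the carbonyl carbon would compare with 1-bromoethyl.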